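This account rests on a few compounds, and the source may have more. Where it says the series, first, only, none or still open, it means among the compounds named here.

Of the compounds shown here, three sharing one core have been measured in a functional assay on HepG2 cells (Homo sapiens) for inhibition, read by MTT assay, with a stated time of 72 h; on this read-out higher numbers stand for weaker inhibition and lower numbers for stronger inhibition. Compound 1 `COc1cccc(-n2cc(COc3cccc(NC(=O)Nc4ccc(Cl)c(C(F)(F)F)c4)c3)nn2)c1` carries a 3-methoxyphenyl group on an aromatic nitrogen and in this assay compound 1 gives 1310 nM. Compound 2 `Cc1ccccc1-n1cc(COc2cccc(NC(=O)Nc3ccc(Cl)c(C(F)(F)F)c3)c2)nn1` carries a 2-methylphenyl group instead, and compound 2 gives 3440 nM. Compound 3 `CCc1ccccc1-n1cc(COc2cccc(NC(=O)Nc3ccc(Cl)c(C(F)(F)F)c3)c2)nn1` carries a 2-ethylphenyl group, and compound 3 gives 3530 nM. Compound 3 sits at the top of the three numbers, but a 1.0-fold higher number from compound 2 to compound 3 (0.01 log units; within the scatter) lies within the scatter, so compounds 2 and 3 cannot be told apart; compound 1, however, does stand apart, since a 2.7-fold higher number from compound 1 to compound 3 (0.43 log units; beyond the scatter) and a 2.6-fold higher number from compound 1 to compound 2 (0.42 log units; beyond the scatter) both go beyond it.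

Compound 4 `CC(C)c1cccc(-n2cc(COc3cccc(NC(=O)Nc4ccc(Cl)c(C(F)(F)F)c4)c3)nn2)c1` is not yet measured. It differs from compound 3 in one place: 3-isopropylphenyl in place of 2-ethylphenyl on an aromatic nitrogen. Among the compounds with values here, no measured step swaps a 2-substituted phenyl for a 3-substituted one of this kind, so the closest guide is that the only 3-substituted phenyl here, compound 1, gives the lowest number, 1310 nM, while lengthening the chain in the 2-position gave a 1.0-fold higher number from compound 2 to compound 3 (0.01 log units; within the scatter). Compound 4 is therefore expected to give a number somewhat lower than compound 3, estimated as a 1.6-fold lower number from compound 3 to compound 4 (0.21 log units; within the scatter) in this assay. The estimate for compound 4 is 2200 nM, with a range from 900 nM to 5500 nM.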

Compound 4, half-maximal inhibitory concentration: 3250 nM
Beside the measured number, compound 4's estimate is 1.5-fold (0.17 log units) below it; the measured number falls inside the stated range.
By their numbers in this assay, from the lowest: compound 1; then compounds 4, 2 and 3 (each within the scatter of the next).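

In this assay, the 3-isopropylphenyl group cannot be told apart from either group with a chain in its name's 2-position, with a 1.1-fold lower number from compound 3 to compound 4 (0.04 log units; within the scatter) and a 1.1-fold lower number from compound 2 to compound 4 (0.02 log units; within the scatter), so swapping one of these phenyl groups for the other makes no visible difference here. The earlier compounds left open whether the lower number of compound 1 came with the 3-substituted pattern in general or with the methoxy group itself, and a 2.5-fold higher number from compound 1 to compound 4 (0.39 log units; beyond the scatter) points to the group: with isopropyl in place of methoxy on the same aromatic carbon, the number rises beyond the scatter, and among these four compounds only compound 1 stands apart from the rest. Nothing on hand explains the difference between the methoxy and isopropyl groups in this assay.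

From the compounds shown here alone, it remains open whether the methoxy group would keep its advantage on another ring carbon, as in a 2-methoxyphenyl or 4-methoxyphenyl group. Going by these compounds, it is also open whether other groups on the carbon bearing the methoxy group, such as a hydroxyl, an ethoxy, an amine or a carboxylic acid, would match compound 1, go lower still, or join the other three.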